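The source may report more compounds than this note shows. Statements on the series, on what has been measured and on what is new or still open speak of the compounds shown alone.

In a functional assay on DLA cells (Mus musculus) for cytotoxicity, read by LDH release, with a stated time of 48 h (on this read-out lower numbers stand for stronger inhibition and higher numbers for weaker inhibition), compound 1 (`Cc1cc(C(=O)c2ccccc2)ccc1OCC(=O)Nc1nc(-c2ccccc2)cs1`) gives 23000 nM and compound 2 (`Cc1cc(C(=O)c2ccccc2F)ccc1OCC(=O)Nc1nc(-c2ccccc2)cs1`) gives 15600 nM with the two values within the scatter of each other. Compound 3 (`Cc1cc(C(=O)c2ccccc2C)ccc1OCC(=O)Nc1nc(-c2ccccc2)cs1`) has methyl in place of fluoro on an aromatic carbon ortho to a large group (methyl in place of fluoro on an aromatic carbon). Among the compounds with values here, the sole measured step (a 1.5-fold lower number from compound 1 to compound 2 (0.17 log units; within the scatter)) puts fluoro in place of hydrogen at that same carbon, so no step beyond the scatter is expected in this assay for this exchange. The estimated step (a 1.2-fold higher number from compound 2 to compound 3 (0.06 log units; within the scatter)) stays within the scatter. Compound 3 is expected at 18000 nM with an estimated range from 8000 nM to 40000 nM for repeat measurements.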

Compound 3, half-maximal inhibitory concentration: 23700 nM
Compound 3: middle estimate off by 1.3-fold (0.12 log units), on the low side, within the range that was stated.
By their numbers in this assay, from the lowest: compounds 2, 1 and 3 (each within the scatter of the next).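

In this assay, the aromatic carbon ortho to a large group now carries hydrogen, fluoro and methyl, and both a 1.5-fold higher number from compound 2 to compound 3 (0.18 log units; within the scatter) and a 1.0-fold higher number from compound 1 to compound 3 (0.01 log units; within the scatter) stay within the scatter. At this carbon, therefore, 2-methylphenyl cannot be told apart from 2-fluorophenyl or from the unsubstituted phenyl of compound 1. Nothing available explains this flat reading.

As far as these compounds go, whether an amine, a carboxylic acid or a methoxy group on this carbon would give a step beyond the scatter stays open. So does whether fluoro or methyl would read the same on another carbon of this ring.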